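Cell Tolerance of Four Related Compounds in Gastric Cells

The compounds below may be only part of what the source reports. "The series", "measured", "known", "first", "only" and "open" are said of these compounds alone.

Compound 1 `Cc1ccc(-n2cc(-c3ccccc3NS(=O)(=O)c3c[nH]c(=O)[nH]c3=O)nn2)cc1`: 32400 nM
Compound 2 `O=c1[nH]cc(S(=O)(=O)Nc2ccccc2-c2cn(-c3ccccc3F)nn2)c(=O)[nH]1`: > 100000 nM (a limit of the assay)
Compound 3 `Cc1ccc(-n2cc(-c3ccc(NS(=O)(=O)c4c[nH]c(=O)[nH]c4=O)cc3)nn2)cc1`: "not toxic" (no number reported) (no number reported)

In an ADME assay on GES1 cells (Homo sapiens) for cytotoxicity, read by MTT assay, with a stated time of 24 h (a higher number here means that more compound is tolerated, a lower number that less compound is tolerated), compound 1 gives 32400 nM. The change 2-fluorophenyl in place of 4-methylphenyl on an aromatic nitrogen raises tolerance by an at least 3.0-fold higher number from compound 1 to compound 2 (0.48 log units; beyond the scatter). For compound 2 the value is a limit of the assay, not a number, the limit being (the limit of > 100000 nM in this assay, at which 1 of the 3 values shown sits). Compound 3 is reported as "not toxic" (no number reported) in this assay; how its core differs from that of compound 1 is not broken down here. Compound 4 `O=c1[nH]cc(S(=O)(=O)Nc2ccc(-c3cn(-c4ccccc4F)nn3)cc2)c(=O)[nH]1` carries the same change as that step, (2-fluorophenyl in place of 4-methylphenyl on an aromatic nitrogen), here made on compound 3. The earlier step rests on one pair only, so a similar direction is expected but its size is uncertain. Compound 4 is expected to give about 100000 nM in this assay, estimated between 40000 nM and 300000 nM, most likely again reported only as a limit.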

Compound 4, half-maximal cytotoxic concentration: > 100000 nM
Compound 4 was reported as a limit; the forecaster's own chance of this, stated with the estimate: 70%; the middle value sits exactly at the limit.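

No new step can be read between compound 3 and compound 4, since compound 3 has no number and compound 4 only a limit of the assay. The compounds shown leave open how much compound 2 and compound 4 are actually tolerated.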